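The compounds below may be only part of what the source reports. "The series", "measured", "known", "first", "only" and "open" are said of these compounds alone.

Compounds measured in an assay on HEK293 cells for inhibition of Voltage-dependent N-type calcium channel subunit alpha-1B (Homo sapiens), read by FLIPR and calcium flux; on this read-out lower numbers stand for stronger inhibition and higher numbers for weaker inhibition:

compound 1, `NS(=O)(=O)c1cccc(C(F)(F)F)c1` — compound 1 gives > 10000 nM in this assay, a limit of the assay rather than a number.
compound 2, `CS(=O)(=O)c1ccc(C#N)cc1C(=O)N1CCC(N(C2CC2)S(=O)(=O)c2cccc(C(F)(F)F)c2)CC1` — compound 2 gives 670 nM in this assay.

Among the measured compounds shown here, compound 2 holds the only number in this assay; the other entry for compound 1 is a limit (the limit of > 10000 nM in this assay, at which 1 of the 2 values shown sits). For the measured compounds named here, no two measured compounds differ in a single place, so no measured step exists to lean on.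

Compound 3, `CS(=O)(=O)c1cc(C#N)ccc1C(=O)N1CCC(N(C2CC2)S(=O)(=O)c2cccc(C(F)(F)F)c2)CC1`, is yet to be measured in this assay. It carries the same atoms as compound 2, joined differently: 4-cyano-2-(methylsulfonyl)phenyl in place of 5-cyano-2-(methylsulfonyl)phenyl on a carbonyl carbon. Going by the values given here, with no measured step of this kind, the step from compound 2 to compound 3 is expected to be small, likely within the scatter, with a slight lean toward weaker inhibition, that is a 1.3-fold higher number from compound 2 to compound 3 (0.13 log units; within the scatter). Compound 3 is estimated at 900 nM, with a range from 300 nM to 2700 nM.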

Compound 3, half-maximal inhibitory concentration: 450 nM
Compound 3: middle estimate off by 2.0-fold (0.30 log units), on the high side; the range from low to high includes it.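

In this assay, among the compounds shown here, 4-cyano-2-(methylsulfonyl)phenyl in place of 5-cyano-2-(methylsulfonyl)phenyl on the carbonyl carbon gives a 1.5-fold lower number from compound 2 to compound 3 (0.17 log units; within the scatter) and provides the first measured step. The two arrangements of these same atoms therefore cannot be told apart on this read-out, so this change alone does not separate the pair. No measured property shown here bears on this result.

Still open, as far as these compounds go, is whether this position responds to a different group: a carboxylic acid or a primary amine in place of the nitrile, or an ethylsulfonyl group in place of the methylsulfonyl, could yet give a step beyond the scatter. From the compounds shown here alone, the contribution of the cyclopropyl group on the sulfonamide nitrogen also remains open.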